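Thiazolyl to pyrimidinyl on the sulfonamide nitrogen

A few compounds are considered here, and "the series" means these few. Any claim that something is new, unique, unknown or untested is made for them only; others in the source may bear on it.

Measured in a physicochemical assay for solubility; on this read-out lower numbers stand for lower solubility and higher numbers for higher solubility:
- compound 1 `Cn1nccc1-c1cc(C(F)(F)F)ccc1[C@H]1CCOc2cc(S(=O)(=O)Nc3ncccn3)ccc21`: 532000 nM
- compound 2 `O=S(=O)(Nc1nccs1)c1ccc2c(c1)OCC[C@@H]2c1ccc(C(F)(F)F)cc1-c1ccc(F)cn1`: 7000 nM

Of these two, compound 2 stands lowest at 7000 nM, and its gap to compound 1 lies beyond the scatter.

Within the data shown here, compound 3 `O=S(=O)(Nc1ncccn1)c1ccc2c(c1)OCC[C@@H]2c1ccc(C(F)(F)F)cc1-c1ccc(F)cn1` has no measurement yet. It carries pyrimidin-2-yl in place of 1,3-thiazol-2-yl on the sulfonamide nitrogen of compound 2 (pyrimidin-2-yl in place of 1,3-thiazol-2-yl on a sulfonamide nitrogen). Among the measured compounds shown here, no measured pair isolates this change, so the expectation rests on thin evidence.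

Compound 1, which also carries pyrimidin-2-yl on a sulfonamide nitrogen, gives 532000 nM in this assay. Compound 1 also differs from compound 3 elsewhere, so only part of its gap to compound 2 is carried over. A rise beyond the scatter is therefore expected, with the estimated step being a 7.1-fold higher number from compound 2 to compound 3 (0.85 log units; beyond the scatter) in this assay. For compound 3 the estimated value is 50000 nM, with an expected range from 12000 nM to 250000 nM in this read-out.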

Compound 3, solubility: 225000 nM
Compound 3: middle estimate off by 4.5-fold (0.65 log units), on the low side; low and high end bracket the measured number.
By their numbers in this assay, from the lowest: compound 2; then compound 3; then compound 1.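

Compound 3 isolates the change on the sulfonamide nitrogen: in this assay, pyrimidin-2-yl in place of 1,3-thiazol-2-yl gives a 32-fold higher number from compound 2 to compound 3 (1.51 log units; beyond the scatter) with the rest of the structure held constant. With pyrimidin-2-yl kept on that nitrogen, 5-fluoropyridin-2-yl in place of 1-methyl-1H-pyrazol-5-yl on an aromatic carbon gives only a 2.4-fold lower number from compound 1 to compound 3 (0.37 log units; beyond the scatter), so the wide gap between compound 1 and compound 2, which mixed two changes, sits mostly with the sulfonamide nitrogen substituent. Nothing measured here accounts for the size of this step.

The compounds shown leave open whether the step from 1,3-thiazol-2-yl to pyrimidin-2-yl keeps its size when 1-methyl-1H-pyrazol-5-yl replaces 5-fluoropyridin-2-yl on the aromatic carbon, since only one pair isolates this change. They also leave open where other groups on the sulfonamide nitrogen, such as pyridin-2-yl, 1,3-oxazol-2-yl or a simple methyl, would fall relative to these two rings.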